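This account rests on a few compounds, and the source may have more. Where it says the series, first, only, none or still open, it means among the compounds named here.

Three compounds share one core. Compound 1 `CC(C)NCc1ccc(-c2c3ncn(CC4(O)CCN(Cc5ccc(-c6ccco6)cc5Cl)CC4)c(=O)c3nn2C)cc1` gives 29.1 nM in an assay on isolated protein for inhibition of ubiquitin carboxyl-terminal hydrolase 7 (Homo sapiens), with stated times of 30 min and 2 h; on this read-out lower numbers stand for stronger inhibition and higher numbers for weaker inhibition; compound 2 `Cn1nc2c(=O)n(CC3(O)CCN(Cc4ccc(-c5ccco5)cc4Cl)CC3)cnc2c1-c1ccc(CNCCO)cc1` gives 8.2 nM; compound 3 `Cn1nc2c(=O)n(CC3(O)CCN(Cc4ccc(-c5ccco5)cc4Cl)CC3)cnc2c1-c1ccc(OC(F)F)cc1` gives 179 nM, the highest number of the three, with steps of a 6.2-fold higher number from compound 1 to compound 3 (0.79 log units; beyond the scatter) and a 22-fold higher number from compound 2 to compound 3 (1.34 log units; beyond the scatter) setting it apart. Compound 4 `Cn1nc2c(=O)n(CC3(O)CCN(Cc4ccc(-c5ccco5)cc4Cl)CC3)cnc2c1-c1ccc(F)cc1` differs from compound 3 by fluoro in place of difluoromethoxy on an aromatic carbon. Going by the values given here, no measured step swaps one small neutral group for another; the two steps onto compound 3 only show that loss of the aminomethyl groups raised the number. Compound 4 is therefore expected to stay near compound 3, with a 1.5-fold higher number from compound 3 to compound 4 (0.16 log units; within the scatter) lying within the scatter or slightly upward. The estimate for compound 4 is 260 nM, within 100 nM to 650 nM.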

Compound 4, half-maximal inhibitory concentration: 64.5 nM
The estimate for compound 4 lay 4.0-fold (0.61 log units) above the measured number; measured number outside the range, below it.
By their numbers in this assay, from the lowest: compound 2; then compound 1; then compound 4; then compound 3.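

In this assay, replacing difluoromethoxy with fluoro on the same aromatic carbon gives a 2.8-fold lower number from compound 3 to compound 4 (0.44 log units; beyond the scatter) and so shows that this position still responds when neither group carries an amine. The aminomethyl groups nevertheless keep the lower numbers, with a 2.2-fold higher number from compound 1 to compound 4 (0.35 log units; beyond the scatter) and a 7.9-fold higher number from compound 2 to compound 4 (0.90 log units; beyond the scatter) showing that fluoro recovers only part of the gap. No measurement at hand gives a reason for these steps.

On these data alone, it remains open how a bare hydrogen, a methoxy group or a carboxylic acid would compare at this position. As far as these compounds go, it is also open whether any group without an amine can match the aminomethyl compounds.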